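Two Limits and One Open Anilino Swap

A few compounds are considered here, and "the series" means these few. Any claim that something is new, unique, unknown or untested is made for them only; others in the source may bear on it.

Measured so far in a functional assay on A549 cells (Homo sapiens) for cytotoxicity, read by MTT assay; on this read-out lower numbers stand for stronger inhibition and higher numbers for weaker inhibition
- Compound 1 (`N#Cc1c(F)c(Cl)c2nc(N)nc(N)c2c1F`) gives 30.8 ug/mL
- Compound 2 (`N#Cc1c(F)c(F)c2nc(N)nc(N)c2c1F`) gives > 1000 ug/mL
- Compound 3 (`N#Cc1c(Nc2ccccc2)c(Cl)c2nc(N)nc(N)c2c1F`) gives > 1000 ug/mL
- Compound 4 (`N#Cc1c(Nc2ccc(Cl)cc2)c(F)c2nc(N)nc(N)c2c1F`) is not yet measured

Compound 2 stands at the limit of > 1000 ug/mL in this assay, at which 2 of the 3 values shown sit, and is thus known only as a limit. Its change to compound 4 puts (4-chlorophenyl)amino in place of fluoro on an aromatic carbon, counted as (4-chlorophenyl)amino in place of fluoro on an aromatic carbon in all. The nearest measured change, anilino in place of fluoro, gave an at least 32-fold higher number from compound 1 to compound 3 (1.51 log units; beyond the scatter) and ended at the limit. The other measured change, fluoro in place of chloro, gave an at least 32-fold higher number from compound 1 to compound 2 (1.51 log units; beyond the scatter) and ended there too. Neither shows the number falling, so no step beyond the scatter is expected. The estimate therefore means a number no higher from compound 2 to compound 4 (the limit leaves the size open) as the expected outcome. Compound 4 is expected at 1000 ug/mL with an estimated range from 250 ug/mL to 2500 ug/mL overall.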

Compound 4, half-maximal inhibitory concentration: 115 ug/mL
The estimate for compound 4 lay 8.7-fold (0.94 log units) above the measured number; measured number outside the range, below it.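

In this assay, (4-chlorophenyl)amino in place of fluoro at this carbon, ortho to a cyano group, gave an at least 8.6-fold lower number from compound 2 to compound 4 (0.93 log units; beyond the scatter). Going by these compounds alone, the only earlier swap at this carbon, anilino in compound 3, went the other way, with an at least 32-fold higher number from compound 1 to compound 3 (1.51 log units; beyond the scatter), so an arylamino group here need not end at the limit. Compound 2 is known only as a limit: the limit of > 1000 ug/mL in this assay, at which 2 of the 4 values shown sit.

On these data alone, the two steps start from compounds carrying chloro or fluoro and add different aryl groups, so which difference reverses the direction stays open. Also open, as far as these compounds go, is how a methoxy group on the phenyl ring, or morpholine at this carbon, would read.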